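Swapping a methyl for a phenyl on the cinnamamide ring

A few compounds are considered here, and "the series" means these few. Any claim that something is new, unique, unknown or untested is made for them only; others in the source may bear on it.

Measured compounds:
Compound 1 `CCOC(=O)CC/C(=C\C(=O)Nc1ccc2c(c1)OCCO2)c1ccc(C(C)(C)C)cc1`: 290 nM
Compound 2 `CC(C)(C)c1ccc(/C=C/C(=O)Nc2ccc3c(c2)OCC(=O)N3)cc1`: > 4000 nM
Compound 3 `Cc1ccc(/C=C/C(=O)Nc2ccc3c(c2)OCCO3)cc1`: 1100 nM

All three were tested in a functional assay on CHO cells for inhibition of transient receptor potential cation channel subfamily V member 1 (Homo sapiens); on this read-out higher numbers stand for weaker inhibition and lower numbers for stronger inhibition. Compound 1 gives 290 nM. For compound 2 the value of > 4000 nM is a limit of the assay, not a number. Compound 3, with 1100 nM, stands highest of the two real numbers; its nearest neighbour is compound 1, which sits lower by a margin beyond the scatter.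

Compound 4 `O=C(/C=C/c1ccc(-c2ccccc2)cc1)Nc1ccc2c(c1)OCCO2` has not yet been measured. It differs from compound 3 by phenyl in place of methyl on an aromatic carbon, in words phenyl in place of methyl on an aromatic carbon. Going by the values given here, no measured pair shows this change directly. A moderate step towards stronger inhibition, beyond the scatter, is expected, because compound 1 gives 290 nM. Compound 4 is therefore estimated at 400 nM, with a range from 120 nM to 1300 nM. That estimate means an expected step of a 2.8-fold lower number from compound 3 to compound 4 (0.44 log units; beyond the scatter).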

Compound 4, half-maximal inhibitory concentration: > 4000 nM
Compound 4: a limit, no number; the forecaster's own chance of this, stated with the estimate: 10%; middle value at least 10-fold (1.00 log units) away from the limit.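

In this assay, the value of compound 4 is a limit and not a number: the limit of > 4000 nM in this assay, at which 2 of the 4 values shown sit.

Even so, replacing methyl with phenyl on this aromatic carbon, para to a large group, gives an at least 3.6-fold higher number from compound 3 to compound 4 (0.56 log units; beyond the scatter). Going by these compounds alone, for the first time, a direct pair shows that this single change at this position weakens inhibition, and that the loss is beyond the scatter.

Going by these compounds, the true size of the step remains unknown. On these data alone, it is also open how a methoxy group, a chlorine atom or an amine would behave at this position.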